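Swapping the Aryl Group on an Amide in Melanocortin Binders

The compounds below may be only part of what the source reports. "The series", "measured", "known", "first", "only" and "open" are said of these compounds alone.

Measured in an assay on CHO cells for displacement of a labelled ligand from Melanocortin receptor 5 (Homo sapiens); on this read-out higher numbers stand for weaker inhibition and lower numbers for stronger inhibition:
Compound 1 `CC(C)N(CC(C1CCCCC1)N1CCN(C(=O)[C@@H]2CN(C(C)(C)C)C[C@H]2c2ccc(F)cc2F)CC1)S(C)(=O)=O` gives 250 nM
Compound 2 `CC(C)N(CC(C1CCCCC1)N1CCN(C(=O)[C@@H]2CN(C(C)(C)C)C[C@H]2c2ccc(F)cc2F)CC1)C(=O)c1cccnn1` gives 130 nM

Among the measured compounds shown here, compound 2 holds the lower of the two numbers, but the only measured step, a 1.9-fold lower number from compound 1 to compound 2 (0.28 log units; within the scatter), lies within the scatter, so the two are not separated. Compound 3 `CC(C)N(CC(C1CCCCC1)N1CCN(C(=O)[C@@H]2CN(C(C)(C)C)C[C@H]2c2ccc(F)cc2F)CC1)C(=O)c1cnn(C(C)C)c1` differs from compound 2 in one place: 1-isopropyl-1H-pyrazol-4-yl in place of pyridazin-3-yl on a carbonyl carbon. For the measured compounds named here, no measured step alters the group on this carbonyl carbon; the one step available, a 1.9-fold lower number from compound 1 to compound 2 (0.28 log units; within the scatter), exchanged the whole substituent on the amine nitrogen and still stayed within the scatter. For compound 3 a step of a 1.1-fold higher number from compound 2 to compound 3 (0.03 log units; within the scatter) is therefore expected, no shift beyond the scatter. The estimate for compound 3 is 140 nM, expected between 50 nM and 400 nM.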

Compound 3, half-maximal inhibitory concentration: 620 nM
For compound 3 the middle estimate is 4.4-fold (0.65 log units) below the measured one; measured number above the stated range.
By their numbers in this assay, from the lowest: compounds 2 and 1 (each within the scatter of the next); then compound 3.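

In this assay, among the compounds shown here, the group on this carbonyl carbon turns out to matter: 1-isopropyl-1H-pyrazol-4-yl in place of pyridazin-3-yl gives a 4.8-fold higher number from compound 2 to compound 3 (0.68 log units; beyond the scatter) and is the first change here to clear the scatter. Measured against methylsulfonyl on the amine nitrogen, the (1-isopropyl-1H-pyrazol-4-yl)carbonyl group also gives a 2.5-fold higher number from compound 1 to compound 3 (0.39 log units; beyond the scatter) as a step beyond the scatter, so not every acyl group here matches compound 2. Nothing measured here explains the rise.

As far as these compounds go, whether the higher number follows the five-membered ring or the isopropyl group stays open. A pyrazol-4-yl group carrying methyl instead of isopropyl, or no alkyl group at all, would help separate the two.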